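The compounds below may be only part of what the source reports. "The series", "measured", "known", "first", "only" and "open" are said of these compounds alone.

Measured in a functional assay on the whole organism (strain Wistar) for inhibition, with Rattus norvegicus as the target, read by paw edema, with stated times of 30 min and 3 h, at a dose of 100 mg/kg by the oral route; a lower number here means less inhibition, a higher number more inhibition at the dose given (going by the name of the read-out):
compound 1 `CCOc1cc(C(=O)N(C)C)nn1-c1ccccc1` gives 65.8%
compound 2 `CC(C)Oc1cc(C(=O)N(C)C)nn1-c1ccccc1` gives 43.9%
compound 3 `CCCCOc1cc(C(=O)N(C)C)nn1-c1ccccc1` gives 18.7%

Compound 4 `CCCCCOc1cc(C(=O)N(C)C)nn1-c1ccccc1` is not yet measured. The change from compound 3 to compound 4 is methyl in place of hydrogen on a saturated chain carbon, four bonds along the chain from an oxygen on an aromatic ring. The same kind of change occurs once among the measured pairs, from compound 1 to compound 2, as methyl in place of hydrogen on a saturated chain carbon bound to an oxygen on an aromatic ring and a saturated chain carbon, where it gave a number 21.9 percentage points lower from compound 1 to compound 2 (beyond the scatter). The two cores differ by ethyl in place of hydrogen on a saturated chain carbon, two bonds along the chain from an oxygen on an aromatic ring, and the place is not the same word for word: in the earlier pair the carbon is bound to an oxygen on an aromatic ring and a saturated chain carbon, here it is four bonds along the chain from an oxygen on an aromatic ring. Each lengthening of the chain so far lowered the number, as seen in a number 47.1 percentage points lower from compound 1 to compound 3 (beyond the scatter) and a number 25.2 percentage points lower from compound 2 to compound 3 (beyond the scatter), so a further drop is expected, smaller than the earlier one since compound 3 already stands at 18.7%. For compound 4 the expected step is a number 6.7 percentage points lower from compound 3 to compound 4 (within the scatter). Compound 4 is estimated at 12%, likely between 2% and 28%.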

Compound 4, a percentage reported as inhibition, in the whole organism at one dose (the size of the read-out at that dose, not a potency): 20%
For compound 4 the middle estimate is 8 percentage points below the measured one, and the stated range covers the measured number.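

In this assay, methyl in place of hydrogen does not carry over as one fixed step from one core to another in this series, and the two steps differ: the same change on two cores in this assay, a number 21.9 percentage points lower (beyond the scatter) from compound 1 to compound 2 and a number 1.3 percentage points higher (within the scatter) from compound 3 to compound 4, 23.2 percentage points apart, beyond the scatter of two such steps

The new step reads a number 1.3 percentage points higher from compound 3 to compound 4 (within the scatter), while the pentyl chain of compound 4 still stands clear of the two other ethers, with a number 23.9 percentage points lower from compound 2 to compound 4 (beyond the scatter) and a number 45.8 percentage points lower from compound 1 to compound 4 (beyond the scatter). This does not separate the effect of the core from that of the place, since the carbon carrying the methyl differs between the two pairs and each pair is a single example.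

The compounds shown leave open what a longer chain such as hexyl, or a chain ending in an amine or a carboxylic acid, would give on the oxygen.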